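From 3-hydroxyphenyl to 2-fluorophenyl in one inhibitor series

The compounds below may be only part of what the source reports. "The series", "measured", "known", "first", "only" and "open" are said of these compounds alone.

Measured so far in a functional assay on HL-60 cells (Homo sapiens) for inhibition, read by MTT assay, with a stated time of 72 h (a higher number here means a weaker inhibitor, a lower number a stronger inhibitor), for this series:
Compound 1 `O=C(c1oc(C(F)(F)F)nc1-c1ccccc1F)N1CCN(c2cccc(Cl)c2)CC1` gives "not active" (no number reported) without a number
Compound 2 `Cc1nc(-c2cccc(O)c2)c(C(=O)N2CCN(c3cccc(Cl)c3)CC2)o1` gives 105 nM as its half-maximal inhibitory concentration

The record is thin. Among the measured compounds shown here, compound 2 at 105 nM holds the only number in this assay so far, so it cannot be ranked against a second value. The other entry, compound 1, offers no number to compare with it.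

Compound 3 `Cc1nc(-c2ccccc2F)c(C(=O)N2CCN(c3cccc(Cl)c3)CC2)o1` has not yet been measured. It keeps the rest of compound 2 and changes one group, with 2-fluorophenyl in place of 3-hydroxyphenyl on an aromatic carbon of the five-membered aromatic ring, next to the ring nitrogen: 2-fluorophenyl in place of 3-hydroxyphenyl on an aromatic carbon is the whole difference between them.

For the measured compounds named here, no measured pair shows what a change of this kind does, so the size of the step remains uncertain. The expected change is a 4.8-fold higher number from compound 2 to compound 3 (0.68 log units; beyond the scatter) toward weaker inhibition, an estimate that rests on a single measured number. In this assay compound 3 is expected at about 500 nM within a range of 100 nM to 5000 nM until the measurement is in.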

Compound 3, half-maximal inhibitory concentration: 39.4 nM
Compound 3: middle estimate off by 13-fold (1.10 log units), on the high side, and the stated range ends above it.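

In this assay, this position on the five-membered aromatic ring now has its first measured step, a 2.7-fold lower number from compound 2 to compound 3 (0.43 log units; beyond the scatter), and the number falls even though 2-fluorophenyl carries none of the hydrogen-bond donor and hydrogen-bond acceptor counted on 3-hydroxyphenyl. Compound 3 also shares 2-fluorophenyl with compound 1, which has trifluoromethyl where compound 3 has a methyl group; since compound 3 gives a number in this assay while compound 1 gives "not active" (no number reported), 2-fluorophenyl alone does not leave a compound without a reported value. Nothing measured here accounts for the stronger inhibition seen with 2-fluorophenyl.

The two group names differ in both the atom on the phenyl ring and its numbered place, so the compounds shown cannot separate the contribution of the fluorine from that of its location. Also open, from the compounds shown here alone, is how a plain phenyl, a methoxyphenyl or a pyridyl group would compare at this position, and whether an ethyl group could stand in for the methyl group while inhibition is kept.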